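The source may hold more compounds than are shown below. What is called first, only, known or untested is meant among the compounds shown, and "the series" means these compounds.

Compound 1 `COc1ccc(/C=C/C(=O)CC(C)=O)cc1` serves as the reference point of this set. In a functional assay on MDA-MB-231 cells (Homo sapiens) for cytotoxicity, read by MTT assay, with a stated time of 72 h (on this read-out higher numbers stand for weaker inhibition and lower numbers for stronger inhibition), compound 1 gives 25000 nM. Two further compounds share the same measurement: compound 2 `COc1ccc(/C=C/c2cc(C)no2)cc1` gives 69300 nM, and compound 3 `Cc1cc(/C=C/c2ccc(O)cc2)on1` gives 55500 nM. The difference between the core of compound 1 and the core of compound 2 is not broken down here. Compound 2 and compound 3, however, differ in one place only, (hydrogen in place of methyl on an oxygen on an aromatic ring), and that change produced a 1.2-fold lower number from compound 2 to compound 3 (0.10 log units; within the scatter).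

Compound 4 `CC(=O)CC(=O)/C=C/c1ccc(O)cc1` has not yet been measured. It stands to compound 1 exactly as compound 3 stands to compound 2, namely (hydrogen in place of methyl on an oxygen on an aromatic ring); the place is the same in both pairs, so the change is the same change, methoxy to hydroxy, made on a different core.

Because the earlier instance gave a 1.2-fold lower number from compound 2 to compound 3 (0.10 log units; within the scatter), a step of about the same size is expected here, a 1.1-fold lower number from compound 1 to compound 4 (0.06 log units; within the scatter), which would stay within the scatter. On that basis compound 4 is estimated at 22000 nM in this assay, with a plausible range from 10000 nM to 50000 nM.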

Compound 4, half-maximal inhibitory concentration: 6800 nM
For compound 4 the middle estimate is 3.2-fold (0.51 log units) above the measured one, outside the stated range (below it).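

In this assay, methoxy to hydroxy on the core of compound 1 gave a 3.7-fold lower number from compound 1 to compound 4 (0.57 log units; beyond the scatter), so on this core the change moved the number beyond the usual scatter. Among the compounds shown here, the size of the step therefore did not carry over from one core to the other: the same change on two cores in this assay, a 1.2-fold lower number (0.10 log units; within the scatter) from compound 2 to compound 3 and a 3.7-fold lower number (0.57 log units; beyond the scatter) from compound 1 to compound 4, 2.9-fold (0.47 log units) apart, beyond the scatter of two such steps This shows that the step seen on one core is a poor guide to the step on the other, but it rests on only two pairs, so it does not show which feature of the cores sets the difference, nor does it give a rule for any further core.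

The compounds shown leave open whether an amine, a carboxylic acid or a longer chain such as ethoxy on that same oxygen-bearing place would also give different results on the two cores. They also leave open how a third core would respond to methoxy to hydroxy.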